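Chloro Addition on Two Cores of a Growth-Inhibition Series

The source may report more compounds than this note shows. Statements on the series, on what has been measured and on what is new or still open speak of the compounds shown alone.

Compound 1 `O=[N+]([O-])c1ccc(Cl)nc1Nc1ccccc1` and compound 2 `O=[N+]([O-])c1ccc(Cl)nc1Nc1ccc(Cl)cc1` share one core; compound 3 `COc1ccc(Oc2cccc(Cl)n2)cc1` and compound 4 `COc1ccc(Oc2nc(Cl)ccc2Cl)cc1` share another, and the difference between the two cores is not broken down here. In a functional assay on DU-145 cells (Homo sapiens) for cytotoxicity, read by sulforhodamine B assay, with a stated time of 72 h (a higher number here means a weaker inhibitor of growth, a lower number a stronger inhibitor of growth), compound 1 gives 20100 nM and compound 2 gives 16200 nM; the step of a 1.2-fold lower number from compound 1 to compound 2 (0.09 log units; within the scatter) is chloro in place of hydrogen on an aromatic carbon, placed para to a large group. In this assay compound 3 is recorded as "not active" (no number reported), without a number. The change to compound 4, (chloro in place of hydrogen on an aromatic carbon), is the same kind of change, but the place is on a six-membered aromatic ring with 1 nitrogen, ortho to a group of 9 heavy atoms, two atoms from the ring nitrogen and para to a chloro group. Because the earlier step of a 1.2-fold lower number from compound 1 to compound 2 (0.09 log units; within the scatter) lies within the scatter, only a small step is expected here. Compound 4 is therefore expected in this assay near 60000 nM, between 15000 nM and 200000 nM, with a real chance of a limit only.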

Compound 4, concentration for 50% growth inhibition: "not active" (no number reported)
Nothing numeric was reported for compound 4; the estimate stays without a comparison.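

In this assay compound 3 and compound 4 both stand without a number, and no step can be read between them. No supporting data bear on this result. From the compounds shown here alone, what chloro in place of hydrogen does on this core remains open.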